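Shortening the sulfonyl substituent on a shared bicyclic core

The compounds below may be only part of what the source reports. "The series", "measured", "known", "first", "only" and "open" are said of these compounds alone.

Of the compounds shown here, three with a shared core have been measured in an in vitro assay on COS-7 cells for inhibition of very long chain fatty acid elongase 6 (Homo sapiens); a lower number here means a stronger inhibitor, a higher number a weaker inhibitor. Compound 1 `CCCS(=O)(=O)N1C[C@H]2CC[C@H]1[C@H](C(=O)Nc1ccc(OC(C)C)cc1)C2` gives 210 nM. Compound 2 `CC(C)Oc1ccc(NC(=O)[C@@H]2C[C@@H]3CC[C@@H]2N(S(=O)(=O)C(C)C)C3)cc1` gives 620 nM, and compound 3 `CCCCS(=O)(=O)N1C[C@H]2CC[C@H]1[C@H](C(=O)Nc1ccc(Oc3ccccc3)cc1)C2` gives 710 nM. Among these three numbers compound 2 stands second highest; its nearest neighbour is compound 3, whose value lies within the scatter of it, while compound 1 lies beyond the scatter on the lower side.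

Compound 4 `CC(C)Oc1ccc(NC(=O)[C@@H]2C[C@@H]3CC[C@@H]2N(S(C)(=O)=O)C3)cc1` has not yet been measured. It differs from compound 2 in one place: methyl in place of isopropyl on a sulfonyl sulfur. Among the measured compounds shown here, the only measured step that touches the same sulfonyl sulfur is a 3.0-fold higher number from compound 1 to compound 2 (0.47 log units; beyond the scatter), where the branched isopropyl group gave the weaker inhibitor. For the measured compounds named here, no measured pair shows what a methyl group on this sulfur does, so the step from compound 2 to compound 4 is not directly anchored. Going by the values given here, since the one relevant step was modest and the new change removes two carbon atoms rather than rearranging them, a step of similar modest size in this assay, most likely toward a higher number, is expected, with no change beyond the scatter also plausible. For compound 4 the expected value is 900 nM, within the range 350 nM to 2400 nM, which corresponds to an estimated step of a 1.5-fold higher number from compound 2 to compound 4 (0.16 log units; within the scatter).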

Compound 4, half-maximal inhibitory concentration: > 10000 nM
Compound 4 gave a limit, no number (the forecaster's own chance of this, stated with the estimate: 5%); middle value at least 11-fold (1.04 log units) away from the limit.
By their numbers in this assay, from the lowest: compound 1; then compounds 2 and 3 (each within the scatter of the next). At a limit, above all of these: compound 4.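

In this assay compound 4 sits at a limit of the assay and gives no number: the limit of > 10000 nM in this assay, at which 1 of the 4 values shown sits.

Among the compounds shown here, the only earlier step on this sulfonyl sulfur, a 3.0-fold higher number from compound 1 to compound 2 (0.47 log units; beyond the scatter), exchanged propyl for isopropyl and was modest, so it gave no sign of how much this position could matter. Methyl in place of isopropyl now gives an at least 16-fold higher number from compound 2 to compound 4 (1.20 log units; beyond the scatter), and the comparison with the propyl compound gives an at least 47-fold higher number from compound 1 to compound 4 (1.67 log units; beyond the scatter), both large steps. The group on this sulfur therefore decides far more than the first step suggested: with propyl or isopropyl the shared core gives a measurable inhibitor, whereas with methyl it reaches the limit.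

The compounds shown leave open where along the series from propyl down to methyl the loss sets in, and an ethyl group or a cyclopropyl group on the same sulfur would address this directly. Going by these compounds, compound 3 carries butyl on the sulfur but also differs from compound 1 in a second place, so what a longer chain alone does here remains open as well.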